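Swapping a butyl chain for a pyrrole on the shared core

The source may report more compounds than this note shows. Statements on the series, on what has been measured and on what is new or still open speak of the compounds shown alone.

Compound 1 `COC(=O)c1nc(C)n(-c2cccc(Br)c2)n1`: > 100000 nM in a functional assay on Jurkat cells (Homo sapiens) for inhibition, read by MTT assay, with a stated time of 72 h (on this read-out lower numbers stand for stronger inhibition of growth and higher numbers for weaker inhibition of growth), a limit of the assay.
Compound 2 `COC(=O)c1nc(C)n(-c2ccc(C(F)(F)F)cc2)n1`: 9100 nM in this assay.
Compound 3 `CCCCc1nc(C(=O)OC)nn1-c1ccc(F)cc1`: > 100000 nM in this assay, a limit of the assay.

Compound 3 gives no number in this assay, only a limit, and that limit is the point where two of the three values sit (the limit of > 100000 nM in this assay, at which 2 of the 3 values shown sit). Compound 2 is the only compound among these three with a measured number. No pair of these compounds differs in just one place, so no step between measured compounds is available as a guide.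

Compound 4 `COC(=O)c1nc(-c2ccc[nH]2)n(-c2ccc(F)cc2)n1` is the next compound to be measured. It differs from compound 3 in one place: 1H-pyrrol-2-yl in place of butyl on an aromatic carbon. The step from compound 3 to compound 4 cannot be anchored to a measured precedent, so the expectation rests on the starting point alone. Compound 4 is expected to show the step of an at least 1.6-fold lower number from compound 3 to compound 4 (0.22 log units; that floor lies within the scatter), a modest change in the direction of stronger inhibition, with a real chance that the assay again reports only a limit. The estimate for compound 4 is 60000 nM, within 8000 nM to 300000 nM.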

Compound 4, concentration for 50% growth inhibition: 9010 nM
The estimate for compound 4 lay 6.7-fold (0.82 log units) above the measured number; the range from low to high includes it.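

At this aromatic carbon of the shared core, the group matters for growth inhibition in this assay: 1H-pyrrol-2-yl in place of butyl gives an at least 11-fold lower number from compound 3 to compound 4 (1.04 log units; beyond the scatter). Within the data shown here, the earlier compounds offered no step between neighbours, so this is the first direct reading of a single change on this core. The real size of the step stays unknown, as compound 3 gives only a limit and the step is therefore a floor: the limit of > 100000 nM in this assay, at which 2 of the 4 values shown sit.

The entering group differs from butyl by bringing both a five-membered aromatic ring and a hydrogen-bond donor, and this one step cannot separate the two. A phenyl group or a furan-2-yl group at the same carbon would help to tell whether the ring alone is enough or whether the pyrrole's hydrogen is needed as well.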